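Swapping an aromatic ring for cyclopentyl on the side chain

A few compounds are considered here, and "the series" means these few. Any claim that something is new, unique, unknown or untested is made for them only; others in the source may bear on it.

Measured in an assay on isolated protein for inhibition of aldehyde dehydrogenase 1A1 (Homo sapiens), read by spectrophotometry, tested at 10 uM; on this read-out higher numbers stand for more inhibition at the one concentration tested (going by the name of the read-out) and lower numbers for less inhibition:
- compound 1 `CC(C)=CCn1c(CN2CCN(C(=O)C3CC3)CC2)nc2ccccc21` gives 74.3%
- compound 2 `O=C(C1CC1)N1CCN(Cc2nc3ccccc3n2Cc2ccccc2F)CC1` gives 40.7%
- compound 3 `O=C(C1CC1)N1CCN(Cc2nc3ccccc3n2Cc2ccc(C(F)(F)F)cc2)CC1` gives 37%

Compound 3 holds the lowest number of the three, though compound 2 sits within the usual scatter of it; only compound 1 is clearly higher. Compound 4 `O=C(C1CC1)N1CCN(Cc2nc3ccccc3n2CC2CCCC2)CC1` differs from compound 3 in one place: cyclopentyl in place of 4-(trifluoromethyl)phenyl on a saturated chain carbon bound to an aromatic nitrogen. For the measured compounds named here, two measured steps bear on this. Putting an aromatic ring in place of the non-aromatic group of compound 1 cost a number 33.6 percentage points lower from compound 1 to compound 2 (beyond the scatter) and a number 37.3 percentage points lower from compound 1 to compound 3 (beyond the scatter), while exchanging one aromatic ring for another gave a number 3.7 percentage points lower from compound 2 to compound 3 (within the scatter). Because compound 1 gives 74.3% with a non-aromatic group in the same place and the entering cyclopentyl is again non-aromatic, a rise is expected, a number 21 percentage points higher from compound 3 to compound 4 (beyond the scatter), though not necessarily the full return. Compound 4 is estimated at 58%, in the range 38% to 78%.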

Compound 4, a percentage reported as inhibition, at one concentration (the size of the read-out at that concentration, not a potency): 44.5%
Beside the measured number, compound 4's estimate is 13.5 percentage points above it, within the range that was stated.
By their numbers in this assay, from the lowest: compounds 3, 2 and 4 (each within the scatter of the next); then compound 1.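

In this assay, cyclopentyl gives a number 7.5 percentage points higher from compound 3 to compound 4 (within the scatter) and a number 3.8 percentage points higher from compound 2 to compound 4 (within the scatter), so at this position the non-aromatic ring cannot be told apart from either aromatic group. Being non-aromatic is therefore not enough to match the 2-methylprop-1-en-1-yl group, as cyclopentyl gives a number 29.8 percentage points lower from compound 1 to compound 4 (beyond the scatter) in that comparison. No available evidence explains this difference. Still open, on these data alone, is whether the double bond or the open chain of that group matters, which a saturated 3-methylbutyl chain in the same place could help separate. A chain ending in an amine would also probe a different kind of group here.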